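Three Inactive Pyrazole Amines and a Carbamate Analogue

The source may report more compounds than this note shows. Statements on the series, on what has been measured and on what is new or still open speak of the compounds shown alone.

The study records three compounds whose inhibition of the kinase was tested in an assay on Sf9 cells for inhibition of inhibitor of nuclear factor kappa-B kinase subunit epsilon (Homo sapiens), read by ADP-Glo, with a stated time of 60 min; on this read-out lower numbers stand for stronger inhibition and higher numbers for weaker inhibition. Compound 1 `Cc1[nH]nc(N)c1-c1cccc(Br)c1` reaches only the limit of the assay, giving > 100000 nM rather than a number. Compound 2 `Cc1c(N)n[nH]c1-c1ccc(Cl)c(Cl)c1` likewise returns a limit, > 100000 nM, in this assay. Compound 3 `CCC(=O)n1nc(C)c(-c2ccc(Cl)c(Cl)c2)c1N` is reported at the same limit, > 100000 nM, which is not a measured number either. Among the compounds with values here, compound 3 therefore stands where every value shown stands, at the limit of > 100000 nM in this assay, at which 3 of the 3 values shown sit; no compound in the set lies anywhere else, and no step between measured compounds can be computed.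

Compound 4 `Cc1nn(C(=O)OC(C)(C)C)c(N)c1-c1ccc(Cl)c(Cl)c1` has not yet been measured in this assay. It differs from compound 3 in one place: tert-butoxy in place of ethyl on a carbonyl carbon. Cut one bond further out, the change reads propanoyl to tert-butoxycarbonyl, on a carbonyl carbon whose other neighbour is an aromatic nitrogen. Within the data shown here, with every value in hand sitting at a limit, there is no measured step on which to build a direction, so no change beyond the usual scatter is expected from compound 3 to compound 4. The estimated step from compound 3 to compound 4 is a step that the limit leaves unreadable from compound 3 to compound 4, which means essentially nothing. Compound 4 is expected to give 150000 nM in this assay, between 30000 nM and 1000000 nM, most likely as another limit.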

Compound 4, half-maximal inhibitory concentration: > 100000 nM
Compound 4: no number, only a limit; the forecaster's own chance of this, stated with the estimate: 85%; the middle value is on the limit's open side.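

Compound 4 returns > 100000 nM in this assay, which is a limit and not a number. No step from compound 3 to compound 4 can therefore be read, and the set offers no measured value to compare: the limit of > 100000 nM in this assay, at which 4 of the 4 values shown sit.

The compounds shown leave open whether any change to the shared core gives measurable inhibition in this assay, and how propanoyl and tert-butoxycarbonyl compare.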